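The source may report more compounds than this note shows. Statements on the series, on what has been measured and on what is new or still open speak of the compounds shown alone.

Measured compounds in an assay on HeLa cells for inhibition of Indoleamine 2,3-dioxygenase 1 (Homo sapiens), with stated times of 1 h and 18 h; a lower number here means a stronger inhibitor, a higher number a weaker inhibitor:

Compound 1 `Cc1ccc(NC(=O)Nc2cc(-c3ccc(C(=O)O)cc3)ccc2Oc2ccccc2C(C)(C)C)cc1` gives > 1000 nM, a limit of the assay rather than a number.
Compound 2 `Cc1ccc(NC(=O)Nc2cc(-c3ccccc3C(=O)O)ccc2N(C)C2CCCCC2)cc1` gives 14 nM.
Compound 3 `Cc1ccc(NC(=O)Nc2cc(-c3ccccc3C(=O)O)ccc2N2CCC[C@@H]3CCCC[C@@H]32)cc1` gives 159 nM.

Compound 2 holds the lowest of the two numbers in this assay; its nearest neighbour is compound 3, with an 11-fold higher number from compound 2 to compound 3 (1.06 log units; beyond the scatter). Among the compounds with values here, the only other value, that of compound 1, sits at the limit of > 1000 nM in this assay, at which 1 of the 3 values shown sits.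

Compound 4 `Cc1ccc(NC(=O)Nc2cc(-c3ccccc3C(=O)O)ccc2N(CC2CC2)CC2CC2)cc1` is the next variation on the shared core of compound 2. The change is bis(cyclopropylmethyl)amino in place of cyclohexyl(methyl)amino on an aromatic carbon.

Within the data shown here, the one measured step that bears on this place is an 11-fold higher number from compound 2 to compound 3 (1.06 log units; beyond the scatter), where a larger group replaced cyclohexyl(methyl)amino and the number rose sharply. Compound 4 again exchanges the cyclohexyl(methyl)amino, but for a group that is only one heavy atom larger and carries no fused rings, so a smaller change than that from compound 2 to compound 3 is expected, most likely a rise that stays near or just beyond the scatter.

Compound 4 is therefore estimated at 30 nM, with a range from 10 nM to 100 nM; this means an expected step of a 2.1-fold higher number from compound 2 to compound 4 (0.33 log units; beyond the scatter).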

Compound 4, half-maximal inhibitory concentration: 348 nM
The estimate for compound 4 lay 12-fold (1.06 log units) below the measured number; the whole stated range lies below it.
By their numbers in this assay, from the lowest: compound 2; then compound 3; then compound 4. At a limit, above all of these: compound 1.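

In this assay, bis(cyclopropylmethyl)amino in place of cyclohexyl(methyl)amino, para to the 2-carboxyphenyl group, gives a 25-fold higher number from compound 2 to compound 4 (1.40 log units; beyond the scatter), so this position is sensitive to the amine substituents even without a second six-membered ring in the group. The same group also gives a 2.2-fold higher number from compound 3 to compound 4 (0.34 log units; beyond the scatter), so the number does not follow the heavy-atom count across these three amines, and cyclohexyl(methyl)amino remains the best group shown at this position. Within the data shown here, nothing measured so far accounts for these steps.

On these data alone, it remains open whether the low number depends on the cyclohexyl ring or on the small methyl group on the nitrogen. Cyclopropylmethyl(methyl)amino and cyclohexyl(ethyl)amino would separate these two changes, which are combined in the present step.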